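The source may hold more compounds than are shown below. What is called first, only, known or untested is meant among the compounds shown, and "the series" means these compounds.

Measured in a functional assay on DU-145 cells (Homo sapiens) for inhibition, read by trypan blue exclusion, with a stated time of 96 h; a higher number here means a weaker inhibitor of growth, a lower number a stronger inhibitor of growth:
- compound 1 `Cc1ccc(CS/C(=C/c2c(O)cc(O)cc2O)C(=O)c2ccc(Cl)cc2)cc1`: 50000 nM
- compound 2 `Cc1ccc(CS/C(=C/c2cc(C)ccc2C)C(=O)c2ccc(Cl)cc2)cc1`: 10000 nM

Of the two numbers, compound 1 has the higher, at 50000 nM, so it is the weaker inhibitor of growth in this assay. Compound 3 `O=C(/C(=C\c1c(O)cc(O)cc1O)Sc1ccccc1Br)c1ccc(Cl)cc1` is still unmeasured and keeps the 2,4,6-trihydroxyphenyl of compound 1. The change is 2-bromophenyl in place of 4-methylbenzyl on a sulfur.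

For the measured compounds named here, only one measured step is available, a 5.0-fold lower number from compound 1 to compound 2 (0.70 log units; beyond the scatter). It is modest and beyond the scatter, but it swaps 2,5-dimethylphenyl for 2,4,6-trihydroxyphenyl on a double-bonded chain carbon and leaves the group on the sulfur untouched. Going by the values given here, no measured step addresses the sulfur, so that step offers only a rough scale and no direction. A small change is therefore expected, with a slight lean towards a lower number that the data do not firmly support. The estimated step, a 1.7-fold lower number from compound 1 to compound 3 (0.22 log units; within the scatter), is expected to stay within the scatter. For compound 3 the estimated value is 30000 nM, with an expected range of 10000 nM to 90000 nM.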

Compound 3, concentration for 50% growth inhibition: > 100000 nM
Compound 3 ended at the assay's limit; the forecaster's own chance of this, stated with the estimate: 20%; middle value at least 3.3-fold (0.52 log units) from the limit.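

In this assay the group on the sulfur now has a measured step of its own, which compound 2 could not give: 2-bromophenyl in place of 4-methylbenzyl gives an at least 2.0-fold higher number from compound 1 to compound 3 (0.30 log units; that floor lies within the scatter). Compound 3 carries a limit and not a number, the only such reading among the compounds shown: the limit of > 100000 nM in this assay, at which 1 of the 3 values shown sits. The step is therefore only a floor, and that floor lies within the scatter, so its true size cannot be read; what it does show is that, with the 2,4,6-trihydroxyphenyl kept, this change on the sulfur yields no stronger inhibitor of growth than compound 1.

The compounds shown leave open how far compound 3 lies past that floor, and whether 2-bromophenyl on the sulfur would read the same alongside the 2,5-dimethylphenyl of compound 2. They also leave open which part of the change matters, since an unsubstituted phenyl or benzyl on the sulfur would separate the bromine from the rest, and how a longer chain ending in an amine would read at this place.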